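The compounds below may be only part of what the source reports. "The series", "measured", "known", "first", "only" and "open" are said of these compounds alone.

Working notes on the amide-side variation of the shared core.

Compound 1 `COc1ccc(/C=C/C(=O)Nc2cc3c(Nc4ccc(F)c(Cl)c4)ncnc3cc2O[C@H]2CCOC2)c(OC)c1` in a functional assay on A549 cells (Homo sapiens) for cytotoxicity, read by MTT assay, with a stated time of 72 h (on this read-out higher numbers stand for weaker inhibition and lower numbers for stronger inhibition), gives 9350 nM, the lowest of the two numbers in hand. Compound 2 `COc1cc2ncnc(Nc3ccc(F)c(Cl)c3)c2cc1NC(=O)/C=C/c1ccccc1[N+](=O)[O-]` gives 33300 nM in this assay, a weaker value that lies beyond the scatter from compound 1. Compound 3 `COc1cc(/C=C/C(=O)Nc2cc3c(Nc4ccc(F)c(Cl)c4)ncnc3cc2OC)cc(OC)c1` is reported in this assay as "not active" (no number reported), so no number is available for it. Within the data shown here, with two numbers and one entry without a number, no trend can be drawn from these three, and no pair of them differs in only one place.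

Compound 4 `O=C(/C=C/c1ccc(F)cc1Cl)Nc1cc2c(Nc3ccc(F)c(Cl)c3)ncnc2cc1O[C@H]1CCOC1` has not yet been measured. It differs from compound 1 as follows: 2-chloro-4-fluorophenyl in place of 2,4-dimethoxyphenyl on a double-bonded chain carbon bound to a double-bonded chain carbon. Nothing in the measured set tests this particular change, so the expectation rests on compound 1 alone, and the expected step is a 1.2-fold lower number from compound 1 to compound 4 (0.07 log units; within the scatter), small, with no direction beyond the scatter favoured. Compound 4 is estimated at 8000 nM in this assay, with a range from 2500 nM to 25000 nM.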

Compound 4, half-maximal inhibitory concentration: 5190 nM
Compound 4: middle estimate off by 1.5-fold (0.19 log units), on the high side, and the stated range covers the measured number.
By their numbers in this assay, from the lowest: compounds 4 and 1 (each within the scatter of the next); then compound 2.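

Within this assay, the exchange of 2,4-dimethoxyphenyl for 2-chloro-4-fluorophenyl on a double-bonded chain carbon bound to a double-bonded chain carbon gives a 1.8-fold lower number from compound 1 to compound 4 (0.26 log units; within the scatter), the first step in this set that differs in one place. At this position, the change removes the hydrogen-bond acceptors counted on the leaving group and replaces both ring substituents with halogens, yet the two numbers are not separated beyond the scatter. No supporting measurement bears on why the two groups read alike.

Compound 2 and compound 3 differ from compound 4 in more than one place, so their aryl groups cannot be read against this result. From the compounds shown here alone, how an amine or a carboxylic acid on the same phenyl ring would read in this assay remains open.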